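The source may hold more compounds than are shown below. What is called first, only, known or untested is meant among the compounds shown, and "the series" means these compounds.

Measured so far:
- compound 1, `O=C1CCC(N2C(=O)c3cccc(OCCOCCOCCOCc4ccccc4)c3C2=O)C(=O)N1`: 46%
- compound 2, `O=C(COc1ccc2c(c1)C(=O)N(C1CCC(=O)NC1=O)C2=O)NCCOCCOCCOCc1ccccc1`: 15%
- compound 3, `O=C1CCC(N2C(=O)c3cccc(NCCOCCOCCOCc4ccccc4)c3C2=O)C(=O)N1`: 80%

The three compounds were examined in a physicochemical assay, read by HPLC, with a stated time of 24 h, at pH 7.4; on this read-out lower numbers stand for a less stable compound and higher numbers for a more stable compound. Compound 1 gives 46% and stands second highest of the three numbers. Its nearest neighbour is compound 2, whose value of 15% lies a good way lower, beyond the scatter. The furthest is compound 3, whose value of 80% lies higher, also beyond the scatter. No pair of these compounds differs in only one place, so no single step between measured compounds can be read from them; the differences show only what the two values of each pair show.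

The piece now follows the step from compound 1 to the unmeasured compound 4, `O=C1c2cccc(OCCOCCOCCOCc3ccccc3)c2C(=O)N1C1CCCCC1`. The change is cyclohexyl in place of 2,6-dioxopiperidin-3-yl on an amide-type nitrogen in a ring. No measured pair shows a step of this kind in this assay, so the expectation rests on compound 1 alone. An upward step is expected, estimated as a number 39 percentage points higher from compound 1 to compound 4 (beyond the scatter). Compound 4 is therefore expected to show 85% in this assay, with a range from 60% to 98%.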

Compound 4, percent of the compound remaining: 90%
Beside the measured number, compound 4's estimate is 5 percentage points below it, and the stated range covers the measured number.
By their numbers in this assay, from the lowest: compound 2; then compound 1; then compounds 3 and 4 (each within the scatter of the next).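

Among these compounds, the step from the 2,6-dioxopiperidin-3-yl group to cyclohexyl is the first comparison here in which only one place changes, so it can be read directly. In this assay, this swap on the amide-type nitrogen gives a number 44 percentage points higher from compound 1 to compound 4 (beyond the scatter), while the long chain and the rest of the core stay the same. The gap between the two numbers therefore goes with the group on that nitrogen, which shows that this position alone can strongly change how much compound remains, although nothing shown here explains why the swap has so large an effect.

Among the compounds shown here, the result covers only one pair, so it cannot yet be said whether cyclohexyl would give a similar step when placed on the core of compound 2 or compound 3, whose chains are attached differently. It also leaves open which part of the departing group matters, and a piperidine ring with only one carbonyl, or a plain methyl group on the same nitrogen, would help to separate the effect of the ring from that of its carbonyl groups.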